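Series notes: amide tail variation on the sulfonamide core

The compounds below may be only part of what the source reports. "The series", "measured", "known", "first", "only" and "open" are said of these compounds alone.

Compound 1 `CC(=O)NCc1cccc(Cn2nc(NS(=O)(=O)c3ccc(Cl)s3)c3c(Cl)cccc32)c1` gives 3.8 in a physicochemical assay for lipophilicity; on this read-out lower numbers stand for lower lipophilicity and higher numbers for higher lipophilicity. For the measured compounds named here, compound 2 `CC(=O)NCc1cccc(Cn2nc(NS(=O)(=O)c3ccc(Cl)s3)c3c(O)cccc32)c1` gives 2.9 in this assay, and the one single-point step measured so far, a number 0.90 log units lower from compound 1 to compound 2 (beyond the scatter), comes from that pair. Compound 3 `COc1cccc2c1c(NS(=O)(=O)c1ccc(Cl)s1)nn2Cc1cccc(CNC(=O)C2CCO2)c1` gives 4.5 in this assay, the highest of the three numbers shown, standing beyond the scatter above compound 1 and further still above compound 2.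

Compound 4 `CN[C@H](C)C(=O)NCc1cccc(Cn2nc(NS(=O)(=O)c3ccc(Cl)s3)c3c(OC)cccc32)c1` is not yet measured. It differs from compound 3 by 1-(methylamino)ethyl in place of oxetan-2-yl on a carbonyl carbon. Going by the values given here, no measured step touches the amide tail; the only step available, from chloro to hydroxy on an aromatic carbon, concerns a different part of the molecule and gives no direct guide. The exchange counted under the difference replaces a ring bearing no hydrogen-bond donor with an open chain bearing one, so compound 4 is expected to land lower than compound 3 in this assay, the estimated step being a number 1.50 log units lower from compound 3 to compound 4 (beyond the scatter). Compound 4 is therefore estimated at 3, within a range from 2.2 to 3.8.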

Compound 4, distribution coefficient: 3.1
Compound 4: the middle estimate sits 0.10 log units below what was measured, and the stated range covers the measured number.
By their numbers in this assay, from the lowest: compounds 2 and 4 (each within the scatter of the next); then compound 1; then compound 3.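

For the compounds shown here, the amide tail now proves to be a position that moves the read-out in this assay: 1-(methylamino)ethyl in place of oxetan-2-yl on a carbonyl carbon gives a number 1.40 log units lower from compound 3 to compound 4 (beyond the scatter) and is the first step read at this position. Both groups hold 4 heavy atoms, so this change of the same counted size still shifts the number beyond the scatter, while the ring goes, nitrogen replaces oxygen and 1 hydrogen-bond donor enters along with 1 defined stereocentre. One pair cannot separate these differences, and no supporting measurement is available to explain the step.

Still open, going by these compounds, is whether an open chain without the amine, such as an isopropyl group, or a ring carrying the amine, such as azetidin-2-yl, would sit nearer compound 3 or compound 4. The opposite stereoisomer of the 1-(methylamino)ethyl group and a carboxylic acid on the same carbonyl carbon also remain unplaced.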